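The source may hold more compounds than are shown below. What is called first, only, known or untested is meant among the compounds shown, and "the series" means these compounds.

Three compounds have been measured so far in an assay on isolated protein for inhibition of Calpain-1 catalytic subunit (Sus scrofa); a lower number here means a stronger inhibitor, a higher number a weaker inhibitor:

compound 1, `O=C(O)/C(S)=C/c1c[nH]c2cc(Cl)ccc12`, 100 nM
compound 2, `O=C(O)/C(S)=C/c1c[nH]c2cc(F)ccc12`, 300 nM
compound 3, `O=C(O)/C(S)=C/c1c[nH]c2cccc(F)c12`, 300 nM

Compound 2 and compound 3 are built from the same atoms joined differently; the difference between the two cores is not broken down here. In this assay compound 3 gives 300 nM and compound 2 gives 300 nM, level at the digits reported, and together they give the highest numbers of the three. Going by the values given here, the one counted step among the measured compounds is chloro in place of fluoro on an aromatic carbon, which produced a 3.0-fold lower number from compound 2 to compound 1 (0.48 log units; beyond the scatter).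

Compound 4, `O=C(O)/C(S)=C/c1c[nH]c2cccc(Cl)c12`, has not yet been measured. It differs from compound 3 by chloro in place of fluoro on an aromatic carbon. Among the compounds with values here, this is the same kind of change as the one from compound 2 to compound 1, but not the same: in the earlier pair the carbon is meta to a fused ring and para to a fused ring, whereas in compound 4 it is ortho to a fused ring and meta to a fused ring. Set beside a 3.0-fold lower number from compound 2 to compound 1 (0.48 log units; beyond the scatter), the step expected from compound 3 to compound 4 is a 2.3-fold lower number from compound 3 to compound 4 (0.36 log units; beyond the scatter), resting on that single earlier step and tempered by the different place of the carbon. For compound 4 the estimate in this assay is 130 nM, within a range from 50 nM to 350 nM.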

Compound 4, half-maximal inhibitory concentration: 140 nM
Compound 4: the middle estimate sits 1.1-fold (0.03 log units) below what was measured; the range from low to high includes it.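

In this assay, chloro in place of fluoro on an aromatic carbon gives a lower number once more, with a 2.1-fold lower number from compound 3 to compound 4 (0.33 log units; beyond the scatter), this time at a carbon that is ortho to a fused ring and meta to a fused ring. Set beside the earlier step, the change carries from one core to the other with no difference in size that can be told from the scatter: the same change on two cores in this assay, a 3.0-fold lower number (0.48 log units; beyond the scatter) from compound 2 to compound 1 and a 2.1-fold lower number (0.33 log units; beyond the scatter) from compound 3 to compound 4, 1.4-fold (0.15 log units) apart, within the scatter of two such steps. This shows that the change held in these two places, but two pairs make no rule for other places on the ring, and they do not show why chloro gives the lower number.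

The compounds shown carry only fluoro or chloro on the six-membered ring, so it remains open whether bromo, methyl or methoxy would follow the same course. Also open, going by these compounds, is whether the step would hold if an amide took the place of the carboxylic acid.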